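A Piperidinyl Swap at a Basic Ring Nitrogen

The compounds below may be only part of what the source reports. "The series", "measured", "known", "first", "only" and "open" are said of these compounds alone.

compound 1, `Cc1ccc2c(NCc3ccc(NC(=O)C4CCN(Cc5ccccc5)CC4)cc3)nc(N3CCC3)nc2c1`, reported only as a limit in a functional assay on SV5A8 cells (Homo sapiens) for cytotoxicity; on this read-out higher numbers stand for weaker inhibition and lower numbers for stronger inhibition: > 8500 nM
compound 2, `Cc1ccc2c(NCc3ccc(NC(=O)C4CCN(Cc5cccc(F)c5)CC4)cc3)nc(N(C)C)nc2c1`, reported only as a limit in this assay: > 4170 nM

Compound 2 stands at a limit rather than a number in this assay; (the limit of > 4170 nM in this assay, at which 1 of the 2 values shown sits). Compound 1 is likewise a limit; (the limit of > 8500 nM in this assay, at which 1 of the 2 values shown sits). Going by the values given here, neither value is a number, so no step between the two measured compounds can be sized, and no pattern can be drawn from them.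

Compound 3, `Cc1ccc2c(NCc3ccc(NC(=O)C4CCN(CC5CCNCC5)CC4)cc3)nc(N(C)C)nc2c1`, differs from compound 2 by piperidin-4-yl in place of 3-fluorophenyl on a saturated chain carbon bound to an amine nitrogen in a ring. Among the compounds with values here, with both measured compounds sitting at limits, there is no measured step to guide the expectation, and the only anchor is the shared core with its limit. The step is expected to be a step that the limit leaves unreadable from compound 2 to compound 3, essentially no change beyond the scatter, in either direction. Compound 3 is therefore expected at 6000 nM, within a range from 1500 nM to 25000 nM, and most probably the measurement again returns only a limit.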

Compound 3, half-maximal inhibitory concentration: > 8070 nM
Compound 3: only a limit was reported; the forecaster's own chance of this, stated with the estimate: 70%; at least 1.3-fold (0.12 log units) between middle value and limit.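

Compound 2 and compound 3 were both reported only as limits in this assay, and the step between them cannot be read. The compounds shown leave open how piperidin-4-yl in place of 3-fluorophenyl acts in this assay, as none of them gives a number rather than a limit.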